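A few compounds are considered here, and "the series" means these few. Any claim that something is new, unique, unknown or untested is made for them only; others in the source may bear on it.

Working notes on the series. Compound 1 `COc1ncc(-c2ccc3nc(NC(=O)NCCN(C)C)sc3c2)cc1NS(=O)(=O)c1ccc(F)cc1` carries a urea on a nitrogen on an aromatic ring, and in a functional assay on U-87MG ATCC cells for antiproliferative activity against U-87 MG (Homo sapiens), read by MTT assay, with a stated time of 72 h (a lower number here means a stronger inhibitor, a higher number a weaker inhibitor), compound 1 gives 1020 nM. Compound 2 `CNC(=O)Nc1nc2ccc(-c3cnc(OC)c(NS(=O)(=O)c4ccc(F)cc4)c3)cc2s1` keeps the urea but with a smaller substituent; in this assay compound 2 gives 1230 nM. Among the measured compounds shown here, the only step measured, a 1.2-fold higher number from compound 1 to compound 2 (0.08 log units; within the scatter), lies within the scatter, so trimming the urea substituent in this pair left the read-out unchanged.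

Compound 3 `CCOC(=O)CNc1nc2ccc(-c3cnc(OC)c(NS(=O)(=O)c4ccc(F)cc4)c3)cc2s1` replaces the urea with an (ethoxycarbonyl)methyl group on the same nitrogen. In this assay, for the measured compounds named here, compound 3 gives "not determined" (no result reported), so its position on the scale is unknown, and no step from it can be quantified.

Compound 4 `COc1ncc(-c2ccc3nc(NC(=O)NCCN4CCN(C)CC4)sc3c2)cc1NS(=O)(=O)c1ccc(F)cc1` differs from compound 3 by (2-(4-methylpiperazin-1-yl)ethyl)carbamoyl in place of (ethoxycarbonyl)methyl on a nitrogen on an aromatic ring. Going by the values given here, no measured step covers this exchange directly, since compound 3 has no value. The nearest measured point is compound 1, which carries a (dimethylamino)methyl-bearing urea on the same nitrogen and gives 1020 nM, while compound 2 gives 1230 nM; both ureas sit in the same range. Compound 4 is therefore expected to fall in that range, and its estimate in this assay is 1000 nM, with a range of 400 nM to 2500 nM.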

Compound 4, half-maximal inhibitory concentration: 440 nM
Beside the measured number, compound 4's estimate is 2.3-fold (0.36 log units) above it, and the stated range covers the measured number.
By their numbers in this assay, from the lowest: compound 4; then compounds 1 and 2 (each within the scatter of the next).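

In this assay, among the compounds shown here, 4-methylpiperazin-1-yl in place of dimethylamino on the saturated chain of the urea gives a 2.3-fold lower number from compound 1 to compound 4 (0.37 log units; beyond the scatter) and is the first change at this nitrogen on an aromatic ring to move the read-out beyond the scatter. Against the smaller urea, the (4-methylpiperazin-1-yl)methyl change gives a 2.8-fold lower number from compound 2 to compound 4 (0.45 log units; beyond the scatter) while a 1.2-fold higher number from compound 1 to compound 2 (0.08 log units; within the scatter) stayed within the scatter, so within these three compounds only the chain ending in the piperazine ring separates from the others, and compound 1 shows that the dimethylamino-ended chain does not. The step is modest, and no measurement at hand bears on why these terminal groups differ.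

The compounds shown leave open whether the shift belongs to the six-membered ring itself or to its methyl group on nitrogen, which a piperazine with an unsubstituted ring nitrogen or a morpholine would separate. They also leave open how the read-out responds to a longer chain between the urea and the ring.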